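This account rests on a few compounds, and the source may have more. Where it says the series, first, only, none or still open, it means among the compounds named here.

Of the compounds shown here, three have been tested in a functional assay on MCF7 cells (Homo sapiens) for antiproliferative activity, read by MTT assay, with a stated time of 72 h (a lower number here means a stronger inhibitor, a higher number a weaker inhibitor), so far. Compound 1 `COc1ccc(-c2cn(C/C=C3\OC(=O)C(OCc4ccccc4)=C3OCc3ccccc3)nn2)cc1` gives 39100 nM. Compound 2 `Cc1ccc(S(=O)(=O)NCc2cn(C[C@H](O)[C@H]3OC(=O)C(OCc4ccccc4)=C3OCc3ccccc3)nn2)cc1` gives 6400 nM, and compound 3 `O=C1O[C@H]([C@@H](O)Cn2cc(-c3cccc(O)c3)nn2)C(OCc2ccccc2)=C1OCc1ccccc1` gives 51800 nM. Among these three numbers compound 1 has the second highest; it is within the scatter of compound 3 and clearly weaker than compound 2. For the measured compounds named here, the only step between two compounds that differ in one place is an 8.1-fold higher number from compound 2 to compound 3 (0.91 log units; beyond the scatter), and that change concerns a different group on a different variant of the shared core.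

Compound 4 `COc1ccccc1-c1cn(C/C=C2\OC(=O)C(OCc3ccccc3)=C2OCc2ccccc2)nn1` differs from compound 1 by one change: 2-methoxyphenyl in place of 4-methoxyphenyl on an aromatic carbon. Both compounds carry the same atoms, joined differently. Going by the values given here, no measured pair in this set moves a methoxy group from one position of the phenyl ring to another, so nothing here bears directly on the step from compound 1 to compound 4. With no evidence for a shift, the expectation is a step of a 1.0-fold higher number from compound 1 to compound 4 (0.01 log units; within the scatter), within the scatter. Compound 4 is therefore estimated to give 40000 nM in this assay, most likely between 15000 nM and 100000 nM.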

Compound 4, half-maximal inhibitory concentration: > 100000 nM
Compound 4: only a limit was reported (the forecaster's own chance of this, stated with the estimate: 15%); middle value at least 2.5-fold (0.39 log units) from the limit.
By their numbers in this assay, from the lowest: compound 2; then compounds 1 and 3 (each within the scatter of the next). At a limit, above all of these: compound 4.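

Compound 4 is reported only as a limit: the limit of > 100000 nM in this assay, at which 1 of the 4 values shown sits.

With 2-methoxyphenyl in place of 4-methoxyphenyl, the data give an at least 2.5-fold higher number from compound 1 to compound 4 (0.40 log units; beyond the scatter), which lies beyond the scatter even though only a lower bound on the step is known. The two groups have the same atoms and the same counts of rings, donors and acceptors, so at this aromatic carbon of the five-membered ring, the way the atoms are joined is enough on its own to change the reading. The earlier step between compounds that differ in one place swapped one group for a quite different one, so it could not show this.

The compounds shown do not tell how far compound 4 actually lies beyond its limit, and they give no cause for the change. On these data alone, how an amine or a chlorine in place of the methoxy group would read also remains open.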